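Aryl changes in the series: the step to compound 4

The compounds below may be only part of what the source reports. "The series", "measured", "known", "first", "only" and "open" are said of these compounds alone.

Measured so far in a functional assay on MCF7 cells (Homo sapiens) for antiproliferative activity, read by MTT assay, with stated times of 24 h and 72 h; a lower number here means a stronger inhibitor, a higher number a weaker inhibitor
- compound 1 `COc1ccc([C@@H]2[C@H](Oc3ccccc3)C(=O)N2c2cc(OC)c(OC)c(OC)c2)cc1` gives 35000 nM
- compound 2 `COc1cc(N2C(=O)[C@@H](Oc3ccccc3)[C@H]2c2ccc(N(C)C)cc2)cc(OC)c1OC` gives 31000 nM
- compound 3 `COc1ccc([C@@H]2[C@H](Oc3ccccc3)C(=O)N2c2cc(OC)c(OC)c(OC)c2)cc1[N+](=O)[O-]` gives 69000 nM

Compound 3 stands at 69000 nM, the largest of the three numbers, though the gap on one side is small (a 2.0-fold higher number from compound 1 to compound 3 (0.29 log units; within the scatter)) and only modest on the other (a 2.2-fold higher number from compound 2 to compound 3 (0.35 log units; beyond the scatter)).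

Compound 4 `COc1cc(N2C(=O)[C@@H](Oc3ccccc3)[C@H]2c2ccc([N+](=O)[O-])cc2)cc(OC)c1OC` has 4-nitrophenyl in place of 4-methoxy-3-nitrophenyl on a saturated ring carbon. Within the data shown here, no measured step removes a methoxy group alone. The nearest evidence is the gain of nitro (a 2.0-fold higher number from compound 1 to compound 3 (0.29 log units; within the scatter)), the change of aryl group (a 2.2-fold higher number from compound 2 to compound 3 (0.35 log units; beyond the scatter)) and the exchange of methoxy for dimethylamino (a 1.1-fold lower number from compound 1 to compound 2 (0.05 log units; within the scatter)). All three are small, so only a small step is expected in this assay, and none clearly beyond the scatter. The expected step is slightly downward (a 1.5-fold lower number from compound 3 to compound 4 (0.19 log units; within the scatter)). The estimate for compound 4 is 45000 nM, with an expected range from 18000 nM to 110000 nM.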

Compound 4, half-maximal inhibitory concentration: 63000 nM
Beside the measured number, compound 4's estimate is 1.4-fold (0.15 log units) below it, and the stated range covers the measured number.
By their numbers in this assay, from the lowest: compounds 2, 1, 4 and 3 (each within the scatter of the next, the first and the last beyond it).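

In this assay, 4-nitrophenyl in place of 4-methoxy-3-nitrophenyl on the saturated ring carbon leaves the number effectively unchanged (a 1.1-fold lower number from compound 3 to compound 4 (0.04 log units; within the scatter)), so the two nitro-bearing aryl groups cannot be told apart here. Against the other two aryl groups the picture is mixed: nitro in place of dimethylamino gives a modest step (a 2.0-fold higher number from compound 2 to compound 4 (0.31 log units; beyond the scatter)), whereas nitro in place of methoxy stays inside the scatter (a 1.8-fold higher number from compound 1 to compound 4 (0.26 log units; within the scatter)), so compound 1 goes against any general separation of the nitro compounds from the rest. Nothing measured here accounts for these small differences.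

Still open, as far as these compounds go, is whether a hydroxyl group or a chlorine on this aryl ring would move the number clearly outside this narrow band. From the compounds shown here alone, the phenoxy group is common to all four compounds, so its contribution remains unknown.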